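The source may report more compounds than this note shows. Statements on the series, on what has been measured and on what is new or still open speak of the compounds shown alone.

Values in a functional assay on HL-60 cells (Homo sapiens) for cytotoxicity, read by WST assay, with a stated time of 48 h (on this read-out lower numbers stand for an effect already at smaller amounts and higher numbers for an effect only at larger amounts of compound), for the measured compounds

compound 1 `COc1ccccc1C[C@H]1COC(=O)[C@@H]1Cc1ccc(Cl)c(Cl)c1` gives 14000 nM
compound 2 `CCOc1ccccc1C[C@H]1COC(=O)[C@@H]1Cc1ccc(Cl)c(Cl)c1` gives 15000 nM
compound 3 `CCCCOc1ccccc1C[C@H]1COC(=O)[C@@H]1Cc1ccc(Cl)c(Cl)c1` gives 10000 nM

Compound 1 stands among values that do not separate, with the steps being a 1.1-fold higher number from compound 1 to compound 2 (0.03 log units; within the scatter) and a 1.4-fold lower number from compound 1 to compound 3 (0.15 log units; within the scatter) and a 1.5-fold lower number from compound 2 to compound 3 (0.18 log units; within the scatter), all within the scatter. The unmeasured compound 4 `O=C1OC[C@H](Cc2cccc(O)c2)[C@H]1Cc1ccc(Cl)c(Cl)c1` carries 3-hydroxyphenyl in place of 2-methoxyphenyl on a saturated chain carbon bound to a saturated ring carbon and this change is the one followed here. The three measured steps bear on it only in part, since each alters the chain on the oxygen and none replaces 2-methoxyphenyl by 3-hydroxyphenyl. For the measured compounds named here, no measured compound carries that group, so the expectation is loose. Since a 1.4-fold lower number from compound 1 to compound 3 (0.15 log units; within the scatter) stays within the scatter, no step beyond the scatter and no firm direction is expected in this assay for this change. The estimated move is a 1.1-fold higher number from compound 1 to compound 4 (0.03 log units; within the scatter) and so no more than the scatter. For compound 4 the expected value is 15000 nM with an estimated range from 6000 nM to 40000 nM as its likely span.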

Compound 4, half-maximal effective concentration: 48000 nM
Compound 4: middle estimate off by 3.2-fold (0.51 log units), on the low side, and the stated range ends below it.
By their numbers in this assay, from the lowest: compounds 3, 1 and 2 (each within the scatter of the next); then compound 4.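

In this assay, putting 3-hydroxyphenyl in place of 2-methoxyphenyl on a saturated chain carbon bound to a saturated ring carbon gives a 3.4-fold higher number from compound 1 to compound 4 (0.54 log units; beyond the scatter). For the compounds shown here, the earlier steps altered only the chain on the oxygen and all stayed within the scatter, so this is the first sign that the read-out responds to a change at this place, and the response is a move towards a higher number. Nothing at hand accounts for this move.

The two groups differ both in where the oxygen stands on the aromatic ring and in the methyl on that oxygen, and the compounds shown do not separate these two changes. Going by these compounds, how 2-hydroxyphenyl, 3-methoxyphenyl or an amine such as 3-aminophenyl would stand at this place remains open.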